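Putting an aromatic ring back on the amine

This account rests on a few compounds, and the source may have more. Where it says the series, first, only, none or still open, it means among the compounds named here.

In a functional assay on MGC-803 cells (Homo sapiens) for inhibition, read by sulforhodamine B assay (on this read-out lower numbers stand for stronger inhibition and higher numbers for weaker inhibition), compound 3 `O=C1C(NC2CCCC2)=CC(=O)c2c1nc1n2[C@H]2OC[C@@H](O)[C@H]2OC1` gives only a limit, > 16000 nM. Compound 1 `O=C1C(Nc2ccc(I)cc2)=CC(=O)c2c1nc1n2[C@H]2OC[C@@H](O)[C@H]2OC1` reaches 2150 nM, and compound 2 `O=C1C(Nc2ccccc2)=CC(=O)c2c1nc1n2[C@H]2OC[C@@H](O)[C@H]2OC1` reaches 1830 nM. Compound 4 `CCc1ccc(NC2=CC(=O)c3c(nc4n3[C@H]3OC[C@@H](O)[C@H]3OC4)C2=O)cc1` has 4-ethylphenyl in place of cyclopentyl on an amine nitrogen. Within the data shown here, three measured steps bear on this. Swapping an aromatic ring for cyclopentyl gave an at least 7.4-fold higher number from compound 1 to compound 3 (0.87 log units; beyond the scatter) and an at least 8.7-fold higher number from compound 2 to compound 3 (0.94 log units; beyond the scatter), both beyond the scatter. Swapping iodo for hydrogen on the ring gave a 1.2-fold lower number from compound 1 to compound 2 (0.07 log units; within the scatter), within the scatter. The change to compound 4 reverses the cyclopentyl swap, so a clear move toward lower numbers is expected. The expected step is an at least 6.9-fold lower number from compound 3 to compound 4 (0.84 log units; beyond the scatter). For compound 4 the estimated value is 2300 nM, with an expected range of 900 nM to 7000 nM.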

Compound 4, half-maximal inhibitory concentration: 1110 nM
The estimate for compound 4 lay 2.1-fold (0.32 log units) above the measured number; low and high end bracket the measured number.
By their numbers in this assay, from the lowest: compounds 4, 2 and 1 (each within the scatter of the next). At a limit, above all of these: compound 3.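

Compound 4 is a third compound with an aromatic ring on the amine nitrogen, and it too sits far from the cyclopentyl compound: an at least 14-fold lower number from compound 3 to compound 4 (1.15 log units; beyond the scatter). Compound 3 gives only a limit: the limit of > 16000 nM in this assay, at which 1 of the 4 values shown sits. Ethyl on the ring gives a 1.6-fold lower number from compound 2 to compound 4 (0.22 log units; within the scatter) and a 1.9-fold lower number from compound 1 to compound 4 (0.29 log units; within the scatter), so hydrogen, iodo and ethyl on that ring carbon cannot be told apart here.

As far as these compounds go, it stays open whether a ring carrying an amine, a carboxylic acid or a longer chain would give numbers in this same range.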